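This account rests on a few compounds, and the source may have more. Where it says the series, first, only, none or still open, it means among the compounds named here.

Of the compounds shown here, three built on one shared core have been tested in a functional assay on MCF7 cells (Homo sapiens) for cytotoxicity, read by MTT assay, with a stated time of 48 h; a lower number here means a stronger inhibitor, a higher number a weaker inhibitor. Compound 1 `COc1ccc2nc(NC(=O)c3cc(-c4ccc(F)cc4)n4nc(-c5ccccc5)cc4n3)sc2c1` gives 24500 nM in this assay. Compound 2 `COc1ccc(-c2cc(C(=O)Nc3nc4ccc(OC)cc4s3)nc3cc(-c4ccccc4)nn23)cc1` differs from compound 1 by methoxy in place of fluoro on an aromatic carbon; in this assay compound 2 gives 19100 nM, which is a 1.3-fold lower number from compound 1 to compound 2 (0.11 log units; within the scatter). Compound 3 `Cc1cc2nc(NC(=O)c3cc(-c4ccc(F)cc4)n4nc(-c5ccccc5)cc4n3)sc2cc1C` differs from compound 1 at the core, namely (5,6-dimethyl-1,3-benzothiazol-2-yl in place of 6-methoxy-1,3-benzothiazol-2-yl on an amide-type nitrogen). In this assay compound 3 gives 17000 nM, a step of a 1.4-fold lower number from compound 1 to compound 3 (0.16 log units; within the scatter). All three values lie within the usual scatter of one another, so none of them can be set apart from the others.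

Compound 4 `COc1ccc(-c2cc(C(=O)Nc3nc4cc(C)c(C)cc4s3)nc3cc(-c4ccccc4)nn23)cc1` has not yet been measured. It differs from compound 3 by methoxy in place of fluoro on an aromatic carbon, the same change as between compound 1 and compound 2, made on the same place in the same words, only on the core of compound 3 rather than that of compound 1. Because the first time this change gave a 1.3-fold lower number from compound 1 to compound 2 (0.11 log units; within the scatter), compound 4 is expected to show 13000 nM in this assay, with a likely range from 6000 nM to 30000 nM. That would amount to an expected step of a 1.3-fold lower number from compound 3 to compound 4 (0.12 log units; within the scatter).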

Compound 4, half-maximal inhibitory concentration: 19700 nM
Compound 4: the middle estimate sits 1.5-fold (0.18 log units) below what was measured, within the range that was stated.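

In this assay, putting methoxy in place of fluoro on the core of compound 3 gives a 1.2-fold higher number from compound 3 to compound 4 (0.06 log units; within the scatter), and putting 5,6-dimethyl-1,3-benzothiazol-2-yl in place of 6-methoxy-1,3-benzothiazol-2-yl on the core of compound 2 gives a 1.0-fold higher number from compound 2 to compound 4 (0.01 log units; within the scatter), so neither change sets the compounds apart. The change from 4-fluorophenyl to 4-methoxyphenyl has no detectable effect on either core, and its two steps cannot be told apart: the same change on two cores in this assay, a 1.3-fold lower number (0.11 log units; within the scatter) from compound 1 to compound 2 and a 1.2-fold higher number (0.06 log units; within the scatter) from compound 3 to compound 4, 1.5-fold (0.17 log units) apart, within the scatter of two such steps This does not show that a real effect carries from one core to another, since steps this small would agree whether or not one existed, and the same limit applies to the change on the amide-type nitrogen: the same change on two cores in this assay, a 1.4-fold lower number (0.16 log units; within the scatter) from compound 1 to compound 3 and a 1.0-fold higher number (0.01 log units; within the scatter) from compound 2 to compound 4, 1.5-fold (0.17 log units) apart, within the scatter of two such steps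

The compounds shown hold only fluoro or methoxy at the aromatic carbon, and only these two benzothiazolyl groups on the nitrogen. On these data alone, whether an amine, a carboxylic acid or a longer chain at that aromatic carbon would give a step beyond the scatter stays open, as does whether such a step would carry over between cores.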